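The source may report more compounds than this note shows. Statements on the series, on what has been measured and on what is new or still open speak of the compounds shown alone.

Compound 1 `Cc1cc(=O)oc2cc(OCC(O)CN3CCC(C(N)=O)CC3)ccc12` — > 100000 nM
Compound 2 `Cc1c(Cc2ccc(Cl)cc2)c(=O)oc2cc(OCC(O)CN3CCC(C(N)=O)CC3)ccc12` — 40000 nM
Compound 3 `Cc1c(Cc2ccccc2C(F)(F)F)c(=O)oc2cc(OCC(O)CN3CCC(C(N)=O)CC3)ccc12` — > 100000 nM

Of the compounds shown here, three sharing one core have been tested in an ADME assay on A549 cells (Homo sapiens) for cytotoxicity, read by CellTiter-Glo; on this read-out higher numbers stand for lower toxicity in this test and lower numbers for higher toxicity in this test. Compound 1 `Cc1cc(=O)oc2cc(OCC(O)CN3CCC(C(N)=O)CC3)ccc12` gives only > 100000 nM, which is a limit of the test rather than a number. Compound 3 `Cc1c(Cc2ccccc2C(F)(F)F)c(=O)oc2cc(OCC(O)CN3CCC(C(N)=O)CC3)ccc12` likewise gives > 100000 nM, again a limit. Among the compounds with values here, compound 2 `Cc1c(Cc2ccc(Cl)cc2)c(=O)oc2cc(OCC(O)CN3CCC(C(N)=O)CC3)ccc12` gives 40000 nM and is the only compound with a true number; the other two values sit at the limit of > 100000 nM in this assay, at which 2 of the 3 values shown sit.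

Compound 4 `Cc1c(Cc2ccc(-c3ccc(Cl)cc3)cc2)c(=O)oc2cc(OCC(O)CN3CCC(C(N)=O)CC3)ccc12` differs from compound 2 in one place: 4-chlorophenyl in place of chloro on an aromatic carbon. Within the data shown here, two measured steps bear on this. Adding the 4-chlorobenzyl group gave an at least 2.5-fold lower number from compound 1 to compound 2 (0.39 log units; beyond the scatter), and swapping to the 2-(trifluoromethyl)benzyl group gave an at least 2.5-fold higher number from compound 2 to compound 3 (0.39 log units; beyond the scatter), so the outer part of that benzyl group has shifted this read-out in both directions. A larger group at that position is therefore expected to change the number only modestly, with a somewhat lower value expected, a 1.3-fold lower number from compound 2 to compound 4 (0.12 log units; within the scatter). Compound 4 is estimated at 30000 nM, within a range from 8000 nM to 100000 nM.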

Compound 4, half-maximal cytotoxic concentration: 32900 nM
For compound 4 the middle estimate is 1.1-fold (0.04 log units) below the measured one; the range from low to high includes it.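

In this assay, 4-chlorophenyl in place of chloro on the aromatic carbon gives a 1.2-fold lower number from compound 2 to compound 4 (0.08 log units; within the scatter). The earlier compounds shown here showed that changing the benzyl group can move this read-out, but they did not show what happens when this one position is enlarged. Here the group grows from one heavy atom to seven and gains a six-membered aromatic ring, yet the step stays within the usual scatter of the test, so this change has no readable effect on the number.

As far as these compounds go, it remains open whether an amine, a carboxylic acid or a longer chain at this same position would also leave the number within the scatter. Few true numbers are available for comparison, and the rest of the series gives only a limit: the limit of > 100000 nM in this assay, at which 2 of the 4 values shown sit.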